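Ring closure on the amine: isopropyl, isobutyl, cyclopentyl

This account rests on a few compounds, and the source may have more. Where it says the series, first, only, none or still open, it means among the compounds named here.

The series rests on a shared core carrying a primary amide and a phenyl group, varied only at the amine substituent. Compound 1 `CC(C)Nc1c(C(N)=O)cnn2cc(-c3ccccc3)cc12` carries an isopropyl group there. In an ADME assay on microsomes (Mus musculus) for metabolic stability, with a stated time of 10 min (on this read-out lower numbers stand for a less stable compound and higher numbers for a more stable compound), compound 1 gives < 50%, which is a limit of the assay rather than a number. Compound 2 `CC(C)CNc1c(C(N)=O)cnn2cc(-c3ccccc3)cc12` carries an isobutyl group instead. In this assay compound 2 gives < 50%, again a limit rather than a number. The step that the two limits leave unreadable from compound 1 to compound 2 therefore cannot be read in size, because of the limit of < 50% in this assay, at which 2 of the 2 values shown sit. Compound 3 `NC(=O)c1cnn2cc(-c3ccccc3)cc2c1NC1CCCC1` differs from compound 2 as follows: cyclopentyl in place of isobutyl on a nitrogen on an aromatic ring. Among the compounds with values here, no measured step sets a direction for this change. Compound 3 is expected to give 30% in this assay, within 5% to 50%, so the step that the limit leaves unreadable from compound 2 to compound 3 is expected to stay within the scatter.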

Compound 3, percent of the compound remaining: < 50%
Compound 3: a limit, no number; the forecaster's own chance of this, stated with the estimate: 70%; the middle value lies beyond the limit too.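

Compound 3 also gives a limit rather than a number in this assay, so no step among compound 1, compound 2 and compound 3 can be read in size: the limit of < 50% in this assay, at which 3 of the 3 values shown sit.

The compounds shown leave open whether isopropyl, isobutyl and cyclopentyl on the amine differ at all in this assay.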